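The compounds below may be only part of what the source reports. "The series", "measured", "known", "first", "only" and "open" are said of these compounds alone.

Compound 1 `COC(=O)Nc1cc(-c2ccc(OC[C@@](C)(N)CC(C)C)c(C)c2)ccn1`, compound 2 `COC(=O)Nc1cc(-c2ccc(OC[C@@](C)(N)CC(C)C)cn2)ccn1` and compound 3 `COC(=O)Nc1cc(-c2cc(C)c(OC[C@@](C)(N)CC(C)C)cn2)ccn1` carry the same carbamate-bearing side and the same amine-bearing ether chain; how the core of compound 1 differs from that of compound 2 is not broken down here. In an ADME assay on microsomes from liver (Rattus norvegicus) for metabolic stability, read by LC-MS, using NADPH, with a stated time of 10 min, tested at 0.5 uM (on this read-out higher numbers stand for a more stable compound and lower numbers for a less stable compound), compound 1 gives 96%, compound 2 gives 100% and compound 3 gives 100%. Compound 3 arises from compound 2 by methyl in place of hydrogen on an aromatic carbon, and this gives no change at the digits printed from compound 2 to compound 3 (within the scatter). Compound 4 `COC(=O)Nc1cc(-c2ccc(OC[C@@](C)(N)CC(C)C)c(C)c2C)ccn1` arises from compound 1 by methyl in place of hydrogen on an aromatic carbon, the same kind of change, but its place differs: in compound 3 the ring holds one nitrogen and the methyl sits ortho to the (2-amino-2,4-dimethylpentyl)oxy group, opposite the ring nitrogen, whereas in compound 4 the ring is carbon only and the methyl sits ortho to a large group, ortho to a methyl group and meta to that oxy group. Because compound 1 already gives 96% in this assay, the expected step is a number 1 percentage points lower from compound 1 to compound 4 (within the scatter), beside the earlier one. Compound 4 is thus expected to give 95%, estimated between 85% and 100%.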

Compound 4, percent of the compound remaining: 83%
The estimate for compound 4 lay 12 percentage points above the measured number; measured number outside the range, below it.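

In this assay, methyl in place of hydrogen on an aromatic carbon gives a number 13 percentage points lower from compound 1 to compound 4 (beyond the scatter). Set beside the earlier step, this does not show that the change behaves differently on the two cores: the same change on two cores in this assay, no change at the digits printed (within the scatter) from compound 2 to compound 3 and a number 13 percentage points lower (beyond the scatter) from compound 1 to compound 4, 13 percentage points apart, within the scatter of two such steps

Nor does it show that the change carries over unchanged, as each core offers only one step and the methyl sits in a different place on each.

On these data alone, it remains open whether a fluorine or a methoxy group in that same place on the core of compound 1 would give a similar step. As far as these compounds go, it also remains open whether an ethyl group there would give a step of another size.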